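Swapping the aryl group on the ring nitrogen

This account rests on a few compounds, and the source may have more. Where it says the series, first, only, none or still open, it means among the compounds named here.

Of the compounds shown here, two have been measured in a functional assay on MCF7 cells (Homo sapiens) for cytotoxicity, read by MTT assay, with a stated time of 72 h; a higher number here means a weaker inhibitor, a lower number a stronger inhibitor. Compound 1 `Cc1cc(=O)n(-c2ccc(F)c(F)c2)nc1C(=O)Nc1ccc(Oc2ncnc3ccsc23)cc1` gives 5550 nM in this assay, and compound 2 `O=C(Nc1ccc(Oc2ncnc3ccsc23)c(F)c1)c1nn(-c2ccc(F)c(Cl)c2)ccc1=O` gives 6630 nM, so the two values sit within the usual scatter of each other. Compound 3 `Cc1ccc(-n2ccc(=O)c(C(=O)Nc3ccc(Oc4ncnc5ccsc45)c(F)c3)n2)cc1` carries 4-methylphenyl in place of 3-chloro-4-fluorophenyl on an aromatic nitrogen. For the measured compounds named here, no step of this kind has been measured here, so no template exists for it; a modest rise in the number, possibly within the scatter, is expected for the step of a 1.4-fold higher number from compound 2 to compound 3 (0.13 log units; within the scatter). Compound 3 is therefore estimated at 9000 nM in this assay, with a range from 3000 nM to 30000 nM.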

Compound 3, half-maximal inhibitory concentration: 23200 nM
Compound 3: the middle estimate sits 2.6-fold (0.41 log units) below what was measured; low and high end bracket the measured number.
By their numbers in this assay, from the lowest: compounds 1 and 2 (each within the scatter of the next); then compound 3.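

In this assay the aryl group on the aromatic nitrogen proves to matter: 4-methylphenyl in place of 3-chloro-4-fluorophenyl brings a 3.5-fold higher number from compound 2 to compound 3 (0.54 log units; beyond the scatter) and so gives a weaker inhibitor. For the compounds shown here, this is the first change at a single place that can be read, and it lies beyond the scatter. No measurement shown here accounts for this step. From the compounds shown here alone, it remains open whether the loss follows the departure of the chlorine and fluorine or the arrival of the methyl, and how an unsubstituted phenyl or a 4-methoxyphenyl would stand at this position.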